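Cyano in Place of Methyl: What to Expect for Compound 4

The source may report more compounds than this note shows. Statements on the series, on what has been measured and on what is new or still open speak of the compounds shown alone.

Of the compounds shown here, three sharing one core have been measured in a functional assay on C6 cells (Rattus norvegicus) for cytotoxicity, read by MTT assay, with a stated time of 24 h, tested at 12 ug/mL; on this read-out lower numbers stand for a stronger effect and higher numbers for a weaker effect at the one concentration tested. Compound 1 `Cc1ccc(-c2cs/c(=N/NC(=O)CSc3nnnn3-c3ccccc3)n2-c2ccccc2)cc1` gives 55.1%, the lowest of the three numbers shown. Compound 2 `Cc1ccc(-c2cs/c(=N/NC(=O)CSc3nnnn3C)n2-c2ccccc2)cc1` gives 68.8%, and compound 3 `Cc1ccc(-c2cs/c(=N/NC(=O)CSc3nnc(C)s3)n2-c2ccccc2)cc1` gives 58.3%. The step of a number 3.2 percentage points higher from compound 1 to compound 3 (within the scatter) lies within the scatter, so compound 1 and compound 3 cannot be told apart on these numbers. The step of a number 13.7 percentage points higher from compound 1 to compound 2 (beyond the scatter) is a modest weakening of the effect, and the step of a number 10.5 percentage points lower from compound 2 to compound 3 (beyond the scatter) is a modest strengthening.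

Compound 4 `N#Cc1ccc(-c2cs/c(=N/NC(=O)CSc3nnnn3-c3ccccc3)n2-c2ccccc2)cc1` differs from compound 1 in a single place: cyano in place of methyl on an aromatic carbon. Cut one bond further out, the change reads 4-methylphenyl becoming 4-cyanophenyl. For the measured compounds named here, none of the measured steps touches this part of the molecule; all three concern the group attached through the sulfur at the far end of the core. Going by the values given here, no measured step therefore bears on this change, and no direction can be read from the data. The expectation is a step of a number 0.1 percentage points lower from compound 1 to compound 4 (within the scatter), that is, nothing beyond the scatter, with a wide range to reflect that uncertainty. Compound 4 is estimated at 55%, within a range from 40% to 72%.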

Compound 4, a percentage reported as activity, at one concentration (the size of the read-out at that concentration, not a potency): 74.1%
Estimate against measurement, compound 4: 19.1 percentage points below; the whole stated range lies below it.
By their numbers in this assay, from the lowest: compounds 1 and 3 (each within the scatter of the next); then compounds 2 and 4 (each within the scatter of the next).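

For the compounds shown here, the earlier compounds changed only the group attached through the sulfur, so this is the first look at the other end of the molecule, at an aromatic carbon para to a large group. In this assay, cyano in place of methyl gives a step of a number 19 percentage points higher from compound 1 to compound 4 (beyond the scatter), a modest weakening of the effect at the one concentration tested, so this position does affect the read-out. Nothing at hand explains the change, so the result records what happens at this position but not why.

With only methyl and cyano shown here, it remains open whether the read-out depends on losing methyl or on gaining cyano, and how it would respond to a plain hydrogen, an amine or a carboxylic acid at the same carbon. From the compounds shown here alone, it is also open whether 4-cyanophenyl in place of 4-methylphenyl would shift the number in the same way when the group on the sulfur is 1-methyl-1H-tetrazol-5-yl or 5-methyl-1,3,4-thiadiazol-2-yl.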